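The compounds below may be only part of what the source reports. "The series", "measured", "known", "first", "only" and "open" are said of these compounds alone.

Measured in an ADME assay on microsomes from liver (Homo sapiens) for metabolic stability; on this read-out lower numbers stand for slow clearance and higher numbers for fast clearance:
Compound 1 `CN1C(=O)C2=C(C1=O)N(CC(=O)Nc1ccc(-c3cccnc3)nc1)CCC2`: 11 mL.min-1.g-1
Compound 2 `CN1C(=O)C2=C(C1=O)N(CC(=O)Nc1ccc(-c3nccs3)cc1)CCC2`: 24 mL.min-1.g-1

Of these two compounds, compound 2 has the higher number, and its gap to compound 1 lies beyond the usual scatter. The next compound, compound 3 `CN1C(=O)C2=C(C1=O)N(CC(=O)Nc1ccc(-c3cccnc3)cc1)CCC2`, differs from compound 2 in one place: pyridin-3-yl in place of 1,3-thiazol-2-yl on an aromatic carbon It has pyridin-3-yl in place of 1,3-thiazol-2-yl on an aromatic carbon, para to a large group.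

Going by the values given here, no measured pair shows this exchange on its own, so the data give no direct size for the step in this assay. Compound 1, which also carries pyridin-3-yl, stands at 11 mL.min-1.g-1, and this points to a small downward step, expected to stay within the scatter. The estimated change is a 1.3-fold lower number from compound 2 to compound 3 (0.12 log units; within the scatter). For compound 3, the expected value is 18 mL.min-1.g-1, with an estimated range of 9 mL.min-1.g-1 to 36 mL.min-1.g-1.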

Compound 3, intrinsic clearance in microsomes: 37 mL.min-1.g-1
Beside the measured number, compound 3's estimate is 2.1-fold (0.31 log units) below it; measured number above the stated range.
By their numbers in this assay, from the lowest: compound 1; then compounds 2 and 3 (each within the scatter of the next).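

In this assay, the exchange of 1,3-thiazol-2-yl for pyridin-3-yl on this aromatic carbon, para to a large group, now has a directly measured size: a 1.5-fold higher number from compound 2 to compound 3 (0.19 log units; within the scatter) for this single pair. On this pair, a six-membered aromatic ring with one hetero atom and a five-membered aromatic ring with two hetero atoms cannot be told apart at this position. Nothing available explains the result or bears on it.

Going by these compounds alone, whether the step keeps this size on another core remains open, as only one pair shows it. Also open, on these data alone, is how a morpholine, a carboxylic acid or a simple alkyl chain on the same carbon would read in this assay, and whether any such group would move the number beyond the scatter.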